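Chloro to methyl on the carbamoyl aryl ring

A few compounds are considered here, and "the series" means these few. Any claim that something is new, unique, unknown or untested is made for them only; others in the source may bear on it.

Measured compounds in a functional assay on NCI-H460 cells (Homo sapiens) for cytotoxicity, read by MTT assay, with a stated time of 72 h; on this read-out higher numbers stand for weaker inhibition and lower numbers for stronger inhibition:
- compound 1 `Cc1ccc(NC(=O)Nc2ccc(-c3nc(NCCN(C)C)c4sccc4n3)cc2)cc1`: 1880 nM
- compound 2 `CCN(CC)CCCNc1nc(-c2ccc(NC(=O)Nc3ccccc3F)cc2)nc2ccsc12`: 370 nM
- compound 3 `CCN(CC)CCCNc1nc(-c2ccc(NC(=O)Nc3ccc(Cl)cc3)cc2)nc2ccsc12`: 81 nM

Compound 3 stands lowest of the three numbers in this assay; the nearest is compound 2 and the furthest compound 1, both beyond the scatter. The next compound, compound 4 `CCN(CC)CCCNc1nc(-c2ccc(NC(=O)Nc3ccc(C)cc3)cc2)nc2ccsc12`, differs from compound 3 in one place: methyl in place of chloro on an aromatic carbon.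

Among the compounds with values here, only one measured step touches the same aryl ring, a 4.6-fold lower number from compound 2 to compound 3 (0.66 log units; beyond the scatter), and it swaps both the substituent and its place on the ring, so it gives a rough scale rather than a direct read. Compound 1 carries the same 4-methylphenyl group as compound 4 but a different amine chain, and its value is far above that of compound 3; with two differences at once, it only hints that the methyl variant may sit higher.

Taken together, a modest rise is expected, a 2.7-fold higher number from compound 3 to compound 4 (0.43 log units; beyond the scatter), and compound 4 is estimated at 220 nM, within 70 nM to 700 nM.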

Compound 4, half-maximal inhibitory concentration: 1240 nM
For compound 4 the middle estimate is 5.6-fold (0.75 log units) below the measured one; measured number above the stated range.
By their numbers in this assay, from the lowest: compound 3; then compound 2; then compounds 4 and 1 (each within the scatter of the next).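

In this assay, methyl in place of chloro on an aromatic carbon para to a large group is a large step (a 15-fold higher number from compound 3 to compound 4 (1.18 log units; beyond the scatter)), so this single substituent carries much of the spread in the series. The comparison with the 2-fluorophenyl compound (a 3.4-fold higher number from compound 2 to compound 4 (0.53 log units; beyond the scatter)) shows that a 4-substituted phenyl does not by itself give the lower number: 4-chlorophenyl lies on one side of 2-fluorophenyl and 4-methylphenyl on the other. The chain change (a 1.5-fold lower number from compound 1 to compound 4 (0.18 log units; within the scatter)) lies within the scatter, so with 4-methylphenyl in place, it shows no readable difference.

No measurement here gives a cause for the chloro-to-methyl step. Still open, from the compounds shown here alone, are how bromo, methoxy or trifluoromethyl would read at this place, and whether the chain change stays within the scatter with 4-chlorophenyl.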